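Methoxy for dimethylamino: a permeability step to be weighed

The source may report more compounds than this note shows. Statements on the series, on what has been measured and on what is new or still open speak of the compounds shown alone.

The pair studied so far shares one core. For the measured compounds named here, compound 1 `Cc1cc(NC(=O)Nc2ccc(C(C)(C)C)cc2)c2ccccc2n1` gives 142 10^-6 cm/s in an ADME assay for permeability, using PAMPA, at pH 7.4 (a higher number here means that the compound crosses the layer faster, a lower number that the compound crosses the layer more slowly), while compound 2 `Cc1cc(NC(=O)Nc2ccc(N(C)C)cc2)c2ccccc2n1` gives 2 10^-6 cm/s in this assay, the lowest of the two numbers seen; the only measured step, a 71-fold lower number from compound 1 to compound 2 (1.85 log units; beyond the scatter), is large and beyond the scatter. Compound 3 `COc1ccc(NC(=O)Nc2cc(C)nc3ccccc23)cc1` differs from compound 2 by methoxy in place of dimethylamino on an aromatic carbon, on an aromatic carbon of a six-membered aromatic ring of carbon only. Going by the values given here, the one step that bears on it, a 71-fold lower number from compound 1 to compound 2 (1.85 log units; beyond the scatter), shows that swapping a group at this carbon can move the number a great deal, though the dimethylamino-to-methoxy swap is not itself measured anywhere in this set. Compound 3 is therefore expected to gain, by a 15-fold higher number from compound 2 to compound 3 (1.18 log units; beyond the scatter), a step beyond the scatter. The estimate for compound 3 in this assay is 30 10^-6 cm/s, with a range from 6 10^-6 cm/s to 120 10^-6 cm/s.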

Compound 3, apparent permeability: 787 10^-6 cm/s
Compound 3: middle estimate off by 26-fold (1.42 log units), on the low side; the whole stated range lies below it.
By their numbers in this assay, from the lowest: compound 2; then compound 1; then compound 3.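

At this position, on an aromatic carbon para to a large group, methoxy in place of dimethylamino gives a 390-fold higher number from compound 2 to compound 3 (2.59 log units; beyond the scatter) in this assay, although the two groups have the same counts of hydrogen-bond donors and acceptors and neither carries a net charge. Methoxy in place of tert-butyl gives a 5.5-fold higher number from compound 1 to compound 3 (0.74 log units; beyond the scatter), so dimethylamino now stands alone at the low end of the three groups and tert-butyl no longer marks the high end. Nothing available here explains either step.

On these data alone, whether the low number belongs to dimethylamino alone or extends to a primary amine or a pyrrolidine at this carbon remains open. So does whether an ethoxy group or a hydroxyl would stay near methoxy, and whether the same swap would behave alike on another core.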